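From 3,5-dimethoxyphenyl to 3,4-dimethoxyphenyl on a carbonyl carbon

The compounds below may be only part of what the source reports. "The series", "measured", "known", "first", "only" and "open" are said of these compounds alone.

In a functional assay on a cell-free system (Platelet, plasma, Homo sapiens) for inhibition (on this read-out lower numbers stand for stronger inhibition and higher numbers for weaker inhibition), compound 3 (`COc1cc(OC)cc(C(=O)N(CCN2CCC(OCC(=O)O)CC2)c2ccc(C)cc2)c1`) gives 530 nM and stands within the scatter of compound 1 (`Cc1ccc(N(CCN2CCC(OCC(=O)O)CC2)C(=O)c2ccc(Cl)cc2)cc1`) at 690 nM as a 1.3-fold lower number from compound 1 to compound 3 (0.11 log units; within the scatter) shows. Compound 2 (`Cc1ccc(N(CCN2CCC(OCC(=O)O)CC2)C(=O)c2cccc(Cl)c2)cc1`) at 100 nM lies apart, with a 5.3-fold higher number from compound 2 to compound 3 (0.72 log units; beyond the scatter) as the gap. Compound 4 (`COc1ccc(C(=O)N(CCN2CCC(OCC(=O)O)CC2)c2ccc(C)cc2)cc1OC`) carries 3,4-dimethoxyphenyl in place of 3,5-dimethoxyphenyl on a carbonyl carbon with 3,4-dimethoxyphenyl in place of 3,5-dimethoxyphenyl on a carbonyl carbon. Among the compounds with values here, the only isomer pair measured is chlorinated, where a 6.9-fold lower number from compound 1 to compound 2 (0.84 log units; beyond the scatter) separates 4-chlorophenyl from 3-chlorophenyl. Within the data shown here, no dimethoxyphenyl isomer pair has been measured, so that step is only a weak guide to a slightly higher number. In this assay the expected step is a 1.1-fold higher number from compound 3 to compound 4 (0.05 log units; within the scatter) and lies within the scatter. Compound 4 is estimated at 600 nM with 200 nM to 1800 nM as the expected range.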

Compound 4, half-maximal inhibitory concentration: > 3000 nM
Compound 4: a limit, no number; the forecaster's own chance of this, stated with the estimate: 1%; middle value at least 5.0-fold (0.69 log units) away from the limit.
By their numbers in this assay, from the lowest: compound 2; then compounds 3 and 1 (each within the scatter of the next). At a limit, above all of these: compound 4.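

In this assay compound 4 gives > 3000 nM, which is a limit and not a number. With the same atoms joined differently, an at least 5.6-fold higher number from compound 3 to compound 4 (0.75 log units; beyond the scatter), so the arrangement of the two methoxy groups on this aryl ring on the carbonyl carbon counts here, as the arrangement of chlorine did in the earlier pair. The other steps, an at least 30-fold higher number from compound 2 to compound 4 (1.47 log units; beyond the scatter) and an at least 4.3-fold higher number from compound 1 to compound 4 (0.63 log units; beyond the scatter), show that dimethoxyphenyl does not always match chlorophenyl at this place, as compounds 1 and 3 alone suggested.

Going by these compounds, how a single methoxy group, a nitrile or a trifluoromethyl group would read at this place stays open.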